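Notes on a pyridyl-oxadiazoline indole series: cytotoxicity limits

The source may hold more compounds than are shown below. What is called first, only, known or untested is meant among the compounds shown, and "the series" means these compounds.

Measured compounds:
compound 1, `COc1ccc(/C=C\C(=O)N2N=C(c3ccncc3)OC2c2c[nH]c3ccccc23)cc1`; in an ADME assay on A549 cells (Homo sapiens) for cytotoxicity, read by MTT assay, with a stated time of 48 h (a higher number here means a weaker inhibitor of growth, a lower number a stronger inhibitor of growth), compound 1 gives > 30 ug/mL, a limit of the assay.
compound 2, `O=C(/C=C\c1ccccc1F)N1N=C(c2ccncc2)OC1c1c[nH]c2ccccc12`; in this assay compound 2 gives > 30 ug/mL, a limit of the assay.
compound 3, `O=C(/C=C\c1ccc(Cl)cc1)N1N=C(c2ccncc2)OC1c1c[nH]c2ccccc12`; in this assay compound 3 gives > 30 ug/mL, a limit of the assay.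

Compound 3 stands where every value in the set stands, at the limit of > 30 ug/mL in this assay, at which 3 of the 3 values shown sit, and no number is read for it. The three measured steps, a step that the two limits leave unreadable from compound 1 to compound 2, a step that the two limits leave unreadable from compound 1 to compound 3 and a step that the two limits leave unreadable from compound 2 to compound 3, each run between two limits and have no readable size, so they set no direction for a further change of the aryl group on the ethenyl chain.

Compound 4, `O=C(/C=C\c1ccc(Br)cc1)N1N=C(c2ccncc2)OC1c1c[nH]c2ccccc12`, is not yet measured in this assay. It differs from compound 3 by bromo in place of chloro on an aromatic carbon. For the measured compounds named here, none of the measured steps covers this change; together they show only that three aryl variants all sit at the limit. The expectation for compound 4 in this assay is therefore a further limit rather than a number, with a step that the limit leaves unreadable from compound 3 to compound 4 that is estimated to stay within the scatter. Compound 4 is estimated at 40 ug/mL, with a range from 15 ug/mL to 120 ug/mL.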

Compound 4, concentration for 50% growth inhibition: > 30 ug/mL
Compound 4 was reported as a limit (the forecaster's own chance of this, stated with the estimate: 80%); the middle value lies beyond the limit too.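

The steps to compound 4 from compound 1, compound 2 and compound 3 each run between two limits, so none of them can be read, and the whole set rests at a single limit: the limit of > 30 ug/mL in this assay, at which 4 of the 4 values shown sit.

On these data alone, how far each of these four compounds lies beyond that limit, and whether any change of the aryl group on the ethenyl chain separates them in this assay remain open.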